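The source may hold more compounds than are shown below. What is called first, only, known or untested is meant among the compounds shown, and "the series" means these compounds.

Two compounds of the series have so far been run in an ADME assay on cells (Hepatocyte, Homo sapiens) for metabolic stability, read by LC-MS, with a stated time of 90 min, tested at 1 uM; a lower number here means slower removal, a higher number faster removal of the compound. Compound 1 `CC(C)n1nc(-c2ccc3oc(N)nc3c2)c2c(C#N)nc(N)nc21` stands at the limit of this assay: in this assay compound 1 gives < 5 uL/min, a limit and not a number. Compound 2 `CC(C)n1nc(-c2ccc3oc(N)nc3c2)c2c(=O)[nH]c(N)nc21` also stands at that limit: in this assay compound 2 gives < 5 uL/min, again a limit rather than a number. Among the measured compounds shown here, both readings rest on (the limit of < 5 uL/min in this assay, at which 2 of the 2 values shown sit), so no step between measured compounds can be counted. Compound 3 `CNc1nc2c(c(-c3ccc4oc(N)nc4c3)nn2C(C)C)c(=O)[nH]1` is not yet measured; it differs from compound 2 by methyl in place of hydrogen on a nitrogen on an aromatic ring. A step within the scatter is expected, an at least 1.2-fold higher number from compound 2 to compound 3 (0.07 log units; that floor lies within the scatter), in this assay. For compound 3 the estimate is 6 uL/min, in the range 3 uL/min to 14 uL/min.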

Compound 3, intrinsic clearance in a liver preparation (reported as CLH), per the amount of preparation that the assay uses: < 5 uL/min
Compound 3: only a limit was reported; the forecaster's own chance of this, stated with the estimate: 50%; at least 1.2-fold (0.07 log units) between middle value and limit.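

Compound 2 and compound 3 give no readable step, because both rest on the same limit and not on a number: the limit of < 5 uL/min in this assay, at which 3 of the 3 values shown sit.

The compounds shown leave open whether methyl in place of hydrogen on a nitrogen on an aromatic ring alters intrinsic clearance at all.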